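The source may hold more compounds than are shown below. What is called first, only, known or untested is meant among the compounds shown, and "the series" means these compounds.

Measured so far:
compound 1, `N#C[Se]c1ccc(NC(=O)OCc2ccc([N+](=O)[O-])cc2)cc1` — 47600 nM
compound 2, `N#C[Se]c1ccc(NC(=O)OCc2ccccc2)cc1` — 50800 nM

In a functional assay on HTB-54 cells (Homo sapiens) for cytotoxicity, read by MTT assay, with a stated time of 72 h (on this read-out higher numbers stand for weaker inhibition of growth and lower numbers for stronger inhibition of growth), compound 1 gives 47600 nM and compound 2 gives 50800 nM. Among the measured compounds shown here, the one measured step is a 1.1-fold higher number from compound 1 to compound 2 (0.03 log units; within the scatter), so the two compounds cannot be told apart on this read-out; compound 2 stands level with compound 1, with no number clear of it.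

Compound 3, `CCCCCCOC(=O)Nc1ccc([Se]C#N)cc1`, is not yet measured. It differs from compound 2 by pentyl in place of phenyl on a saturated chain carbon bound to an oxygen next to a carbonyl group. For the measured compounds named here, no measured step touches this position: the only step recorded, from the nitro to hydrogen on the aromatic ring of the ester part, was within the scatter and concerns a different part of the molecule. Nothing here says whether exchanging a ring for a chain at the carbamate oxygen moves the number. With a single step of no size to go on, the expectation for compound 3 is a number close to that of compound 2, with the range widened to allow for a change in either direction.

Compound 3 is therefore expected at 45000 nM, within 15000 nM to 140000 nM, which means an expected step of a 1.1-fold lower number from compound 2 to compound 3 (0.05 log units; within the scatter).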

Compound 3, concentration for total growth inhibition: 48500 nM
Beside the measured number, compound 3's estimate is 1.1-fold (0.03 log units) below it, and the stated range covers the measured number.
By their numbers in this assay, from the lowest: compounds 1, 3 and 2 (each within the scatter of the next).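

In this assay, pentyl in place of phenyl on a saturated chain carbon bound to an oxygen next to a carbonyl group gives a 1.0-fold lower number from compound 2 to compound 3 (0.02 log units; within the scatter), so at this place the aromatic ring can give way to an open chain with no change that stands clear of the scatter. The earlier step concerned only a substituent on that ring, whereas this one removes the ring itself and still leaves the number unmoved, which shows that, for this pair, a ring at this place is not needed to keep the number. No measurement on hand gives a reason for this result.

The compounds shown cover only phenyl, its nitro-bearing form and pentyl at this place, so they leave open whether a much shorter chain such as methyl, a longer chain such as decyl, or a chain ending in an amine or a carboxylic acid would move the number beyond the scatter. They also leave open what the selenocyanate group contributes, since it is common to all three compounds and no thiocyanate or other replacement stands beside it for comparison.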